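The source may hold more compounds than are shown below. What is called first, only, known or untested is meant among the compounds shown, and "the series" means these compounds.

Compound 1 `CCCCC(OC)c1cccc(NC(=O)CCl)c1` and compound 3 `CCCCC(OC)c1cccc(NC(=O)CCCl)c1` are built on the same core and differ at a single place. In a functional assay on MCF7 cells (Homo sapiens) for antiproliferative activity, with a stated time of 48 h (on this read-out lower numbers stand for stronger inhibition and higher numbers for weaker inhibition), compound 1 gives 12000 nM. Compound 3 reaches only a limit of this assay, > 100000 nM, so no number is known for it. The change that separates them is chloromethyl in place of chloro on a saturated chain carbon bound to a carbonyl carbon, and it brings an at least 8.3-fold higher number from compound 1 to compound 3 (0.92 log units; beyond the scatter). That step rests on (the limit of > 100000 nM in this assay, at which 1 of the 3 values shown sits).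

Compound 2 `O=C(CCCl)Nc1ccc(I)cc1` carries a different core; the difference between the two cores is not broken down here. In this assay compound 2 gives 26000 nM, the higher of the two numbers that are known as numbers, compound 1 sitting lower by a gap beyond the scatter.

Compound 4 `O=C(CCCCl)Nc1ccc(I)cc1` has not been measured. It differs from compound 2 by chloromethyl in place of chloro on a saturated chain carbon, two bonds along the chain from a carbonyl carbon. This is the same kind of change as from compound 1 to compound 3, though not the same: there the changed carbon is bound to a carbonyl carbon, here it sits two bonds along the chain from a carbonyl carbon. Because the first instance gave an at least 8.3-fold higher number from compound 1 to compound 3 (0.92 log units; beyond the scatter), a step of similar direction is expected for compound 4, a 4.6-fold higher number from compound 2 to compound 4 (0.66 log units; beyond the scatter). Since compound 2 already starts at a weaker point than compound 1, compound 4 is expected to land at or past the limit of this assay. Compound 4 is accordingly estimated at about 120000 nM, with a range from 40000 nM to 400000 nM.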

Compound 4, half-maximal inhibitory concentration: > 100000 nM
Compound 4: a limit, no number; the forecaster's own chance of this, stated with the estimate: 60%; the middle value does not contradict the limit.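

Carried onto the core of compound 2, chloromethyl in place of chloro on a saturated chain carbon moves the read-out in this assay the same way as on the core of compound 1, bringing an at least 3.8-fold higher number from compound 2 to compound 4 (0.58 log units; beyond the scatter). Compound 4 sits at a limit of this assay, > 100000 nM, and not at a number: the limit of > 100000 nM in this assay, at which 2 of the 4 values shown sit. The direction of the change therefore carries over between these two cores, but the true size of the step is not known on either of them, and nothing can be said about whether the sizes match: the same change on two cores in this assay, an at least 8.3-fold higher number (0.92 log units; beyond the scatter) from compound 1 to compound 3 and an at least 3.8-fold higher number (0.58 log units; beyond the scatter) from compound 2 to compound 4; the limit leaves it open whether they differ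

The compounds shown leave open whether the same direction would hold on a third core, and how a longer chain ending in chloro would read in this assay. On these data alone, they also leave open whether an amine or a hydroxyl group in place of the chloro at the end of the chain would give a lower or a higher number than the chloro compounds do, so the part played by the chloro itself remains untested here.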